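Series notes: pyridin-4-yl for phenyl on the carbonyl carbon

This account rests on a few compounds, and the source may have more. Where it says the series, first, only, none or still open, it means among the compounds named here.

Compound 1 `COc1ccc(-c2cnc(NC(=O)c3ccccc3O)n2C)cc1`: in a toxicity assay on THP-1 cells (Homo sapiens) for inhibition (on this read-out higher numbers stand for lower toxicity in this test and lower numbers for higher toxicity in this test), compound 1 gives > 100000 nM, which is a limit of the assay and not a number.
Compound 2 `COc1ccc(-c2cnc(NC(=O)c3ccccc3F)n2C)cc1`: in this assay compound 2 gives > 100000 nM, again a limit.
Compound 3 `COc1ccc(-c2cnc(NC(=O)c3ccccc3)n2C)cc1`: in this assay compound 3 gives > 100000 nM, again a limit.

Every value shown sits at the limit of > 100000 nM in this assay, at which 3 of the 3 values shown sit. Compound 3 therefore stands only as a limit, and the steps a step that the two limits leave unreadable from compound 1 to compound 2, a step that the two limits leave unreadable from compound 1 to compound 3 and a step that the two limits leave unreadable from compound 2 to compound 3 cannot be read in size or direction.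

Compound 4 `COc1ccc(-c2cnc(NC(=O)c3ccncc3)n2C)cc1` differs from compound 3 by pyridin-4-yl in place of phenyl on a carbonyl carbon. The three measured steps all alter the same aromatic group on the carbonyl carbon, so they are the ones that bear on this change, yet none of them yields a readable size. What they do show is that every variation of this group so far has left the value at the limit. The expectation for the step that the limit leaves unreadable from compound 3 to compound 4 is therefore no change beyond the scatter, with the result most likely reported again as a limit. Compound 4 is estimated at 150000 nM, with a range from 50000 nM to 500000 nM.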

Compound 4, half-maximal cytotoxic concentration: > 100000 nM
Compound 4: only a limit was reported; the forecaster's own chance of this, stated with the estimate: 85%; the middle value does not contradict the limit.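

In this assay the steps from compound 1, compound 2 and compound 3 to compound 4 cannot be read, since each joins two limits of the assay and no numbers: the limit of > 100000 nM in this assay, at which 4 of the 4 values shown sit.

The compounds shown leave open whether any group on the carbonyl carbon separates these compounds in this assay at all.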